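The source may report more compounds than this note shows. Statements on the series, on what has been measured and on what is new or still open speak of the compounds shown alone.

Compound 3 `C[C@@H]1CN(C(=O)OC(C)(C)C)CCN1c1ncc(OCC2CCN(S(C)(=O)=O)CC2)cn1` gives the highest of the three measured responses in an in vitro functional assay on HEK293S cells with Glucose-dependent insulinotropic receptor (Homo sapiens) as the target, read by HTRF and cAMP accumulation, with a stated time of 45 min (a higher number here means a larger maximal response, a lower number a smaller maximal response), reaching 99%. Compound 2 `CC(C)(C)OC(=O)N1CCN(c2ccc(OCc3ccc(S(C)(=O)=O)cc3)cn2)CC1` reaches 68% in this assay, and compound 1 `CC(C)(C)OC(=O)N1CCN(c2cnc(OCc3ccc(S(C)(=O)=O)cc3)nc2)CC1` reaches 57%; both of these lie beyond the scatter below compound 3. Compound 4 `C[C@@H]1CN(C(=O)OC(C)(C)C)CCN1c1ncc(OCc2ccc(-n3cnnn3)cc2)cn1` keeps the core of compound 3 and differs from it in one place: 4-(1H-tetrazol-1-yl)phenyl in place of 1-(methylsulfonyl)piperidin-4-yl on a saturated chain carbon bound to an oxygen on an aromatic ring. Among the measured compounds shown here, no measured pair of compounds shows this exact change, so its effect is uncertain. Since compounds 1 and 2 both sit lower than compound 3, a drop beyond the scatter is expected, of the size a number 24 percentage points lower from compound 3 to compound 4 (beyond the scatter). Compound 4 is therefore estimated to give 75% in this assay, with a range from 50% to 100%.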

Compound 4, intrinsic activity: the largest response reached, in percent of the reference agonist's: 89%
Compound 4: middle estimate off by 14 percentage points, on the low side, and the stated range covers the measured number.
By their numbers in this assay, from the lowest: compound 1; then compound 2; then compounds 4 and 3 (each within the scatter of the next).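

In this assay, among the compounds shown here, 4-(1H-tetrazol-1-yl)phenyl in place of 1-(methylsulfonyl)piperidin-4-yl gives a number 10 percentage points lower from compound 3 to compound 4 (within the scatter), the first single change that can be read in this set. At this place, on a saturated chain carbon bound to an oxygen on an aromatic ring, the non-aromatic sulfonyl-bearing group can thus give way to two aromatic rings without a drop beyond the scatter. Nothing measured here accounts for this. The compounds shown leave open whether a carboxylic acid or an amine in place of the tetrazole would keep this response. On these data alone, a longer chain at the same place remains equally open.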